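Thiosemicarbazone series: compound 2 to compound 3

The source may hold more compounds than are shown below. What is called first, only, known or untested is meant among the compounds shown, and "the series" means these compounds.

Two compounds of the series carry a number in a functional assay on HT-29 cells (Homo sapiens) for antiproliferative activity, read by sulforhodamine B assay, with a stated time of 72 h (a higher number here means a weaker inhibitor, a lower number a stronger inhibitor), so far. Compound 1 `CN(C)C(=S)N/N=C/c1ccc2cccnc2n1` gives 410 nM in this assay. Compound 2 `N#Cc1ccc(NC(=S)N/N=C/c2ccc3ccccc3n2)cc1` gives 15600 nM in this assay, the higher of the two numbers; compound 1 lies a long way below it, and that gap stands beyond the scatter. Within the data shown here, no two measured compounds differ in a single place, so no measured step is available to lean on.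

Compound 3 `COc1ccc(NC(=S)N/N=C/c2ccc3ccccc3n2)cc1` differs from compound 2 in one place: methoxy in place of cyano on an aromatic carbon. The change sits on a six-membered aromatic ring of carbon only, para to a large group, and swaps one substituent of two heavy atoms for another of two heavy atoms. Nothing measured in the series tells how such a swap moves the number in this assay, so the step from compound 2 to compound 3 is expected to be modest, in either direction, and may well sit within the scatter; the estimated step is a 1.7-fold lower number from compound 2 to compound 3 (0.24 log units; within the scatter). Compound 3 is therefore expected to give about 9000 nM in this assay, with a range from 2500 nM to 35000 nM.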

Compound 3, half-maximal inhibitory concentration: 82300 nM
Compound 3: the middle estimate sits 9.1-fold (0.96 log units) below what was measured, and the stated range ends below it.
By their numbers in this assay, from the lowest: compound 1; then compound 2; then compound 3.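

In this assay, among these compounds, the change from 4-cyanophenyl to 4-methoxyphenyl gives the first measured single-place step, a 5.3-fold higher number from compound 2 to compound 3 (0.72 log units; beyond the scatter), so the number responds to the group at this position on the aromatic ring. The two groups match in what can be counted here: each has two heavy atoms, no ring, no hydrogen-bond donor and one hydrogen-bond acceptor. Those shared counts therefore do not settle the number in this pair, and nothing measured here assigns a reason for the step.

As far as these compounds go, with only nitrile and methoxy compared at this position, it remains open whether other groups there, such as an amine, a carboxylic acid or a chlorine atom, would fall near compound 2, near compound 3 or outside that span. From the compounds shown here alone, it also remains open whether the same exchange would give a step of similar size and direction on another core, since a single pair defines no trend.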